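The compounds below may be only part of what the source reports. "The series", "measured", "known", "first", "only" and "open" are said of these compounds alone.

Compound 1 `COc1cc2c(cc1OC)CN(S(=O)(=O)c1ccc(-n3cc(COc4ccc(C=O)cc4)nn3)cc1)CC2` gives 12500 nM.
Compound 2 `COc1cc2c(cc1OC)CN(S(=O)(=O)c1ccc(-n3cc(COc4ccc5ccccc5c4)nn3)cc1)CC2` gives 1260 nM.

Among the measured compounds shown here, in a functional assay on HepG2 cells (Homo sapiens) for cytotoxicity, read by MTT assay, with a stated time of 48 h (on this read-out higher numbers stand for weaker inhibition and lower numbers for stronger inhibition), compound 2 holds the lower of the two numbers, with compound 1 well above it; the single measured step is a 9.9-fold lower number from compound 1 to compound 2 (1.00 log units; beyond the scatter). Compound 3 `COc1cc2c(cc1OC)CN(S(=O)(=O)c1ccc(-n3cc(COc4ccc(C)cc4)nn3)cc1)CC2` differs from compound 2 in one place: 4-methylphenyl in place of naphthalen-2-yl on an oxygen on a saturated carbon. That measured step bears on this change only loosely, as it exchanges the same naphthalen-2-yl for a different single ring. Losing the second ring is expected to raise the number, so the step from compound 2 to compound 3 is estimated at a 4.0-fold higher number from compound 2 to compound 3 (0.60 log units; beyond the scatter). Compound 3 is therefore expected to give about 5000 nM, within 1500 nM to 16000 nM.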

Compound 3, half-maximal inhibitory concentration: 560 nM
Compound 3: middle estimate off by 8.9-fold (0.95 log units), on the high side; measured number below the stated range.
By their numbers in this assay, from the lowest: compound 3; then compound 2; then compound 1.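

Moving to the single ring of 4-methylphenyl still gives a 2.3-fold lower number from compound 2 to compound 3 (0.35 log units; beyond the scatter) in this assay, so the second ring of naphthalen-2-yl is not needed for a low number at this position. On that single ring, methyl in place of formyl gives a 22-fold lower number from compound 1 to compound 3 (1.35 log units; beyond the scatter), so the group on the aromatic carbon strongly affects the result. No available evidence explains either step. From the compounds shown here alone, how an amine or a carboxylic acid in place of that methyl would behave remains open, as does the outcome for a plain phenyl ring.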